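Swapping Phenoxy for Dimethylamino in Compound 2

The compounds below may be only part of what the source reports. "The series", "measured", "known", "first", "only" and "open" are said of these compounds alone.

In a functional assay on MDA-MB-435 cells (Homo sapiens) for cytotoxicity, read by MTT assay, with a stated time of 72 h (a lower number here means a stronger inhibitor, a higher number a weaker inhibitor), compound 2 `N[C@H]1CC[C@H](Nc2c(C(=O)NCc3ccc(Oc4ccccc4)cc3)nc(Br)c3cccnc23)CC1` gives 4000 nM, within the scatter of compound 1 `NCCCNc1c(C(=O)NCc2ccc(F)cc2)nc(Br)c2cccnc12` at 5000 nM. Compound 3 `O=C(NCc1ccc(F)cc1)c1nc(Br)c2cccnc2c1NCc1ccc(F)cc1` reaches only a limit, > 20000 nM. Compound 4 `CN(C)c1ccc(CNC(=O)c2nc(Br)c3cccnc3c2N[C@H]2CC[C@H](N)CC2)cc1` differs from compound 2 in one place, on an aromatic carbon para to a large group: dimethylamino in place of phenoxy on an aromatic carbon. Among the compounds with values here, the only measured step, an at least 4.0-fold higher number from compound 1 to compound 3 (0.60 log units; beyond the scatter), changes a different place in the molecule, so it offers little guidance here. Within the data shown here, no measured step touches the phenoxy group itself, so no shift beyond the scatter is expected, though with wide uncertainty. The expected change is a 1.1-fold lower number from compound 2 to compound 4 (0.06 log units; within the scatter). For compound 4, the estimated value is 3500 nM, with an expected range from 900 nM to 13000 nM.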

Compound 4, half-maximal inhibitory concentration: 4000 nM
Compound 4: the middle estimate sits 1.1-fold (0.06 log units) below what was measured; the measured number falls inside the stated range.
By their numbers in this assay, from the lowest: compounds 2, 4 and 1 (each within the scatter of the next). At a limit, above all of these: compound 3.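

In this assay, replacing phenoxy with dimethylamino gives no change at the digits printed from compound 2 to compound 4 (within the scatter). Within the data shown here, the aromatic ring of phenoxy can therefore be lost at this place without moving the number, which no earlier step could show, as none touched this group. Nothing measured here explains why the two groups read alike.

Still open, on these data alone, is whether a very different group on this aromatic carbon, such as a carboxylic acid or a primary amine, would also leave the number in place. A longer chain carrying the dimethylamino group poses the same question.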